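A few compounds are considered here, and "the series" means these few. Any claim that something is new, unique, unknown or untested is made for them only; others in the source may bear on it.

Measured compounds:
Compound 1 `Cc1cc(O)c(C2=NN(c3ccc(S(N)(=O)=O)cc3)C(c3ccccc3O)C2)cc1Cl` gives 3690 nM in a functional assay on A549 cells (Homo sapiens) for antiproliferative activity, with a stated time of 48 h; on this read-out lower numbers stand for stronger inhibition of growth and higher numbers for weaker inhibition of growth.
Compound 2 `Cc1cc(O)c(C2=NN(c3ccc(S(N)(=O)=O)cc3)C(c3ccccc3Cl)C2)cc1Cl` gives 3820 nM in this assay.
Compound 3 `Cc1cc(O)c(C2=NN(c3ccc(S(N)(=O)=O)cc3)C(/C=C/c3ccccc3)C2)cc1Cl` gives 11000 nM in this assay.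

Compound 3 has the highest number of the three, meaning the weakest inhibition of growth. Compound 4 `COc1ccc(C2CC(c3cc(Cl)c(C)cc3O)=NN2c2ccc(S(N)(=O)=O)cc2)cc1OC` differs from it by 3,4-dimethoxyphenyl in place of 2-phenylethenyl on a saturated ring carbon. The two steps that bear on this change run the other way: a 3.0-fold higher number from compound 1 to compound 3 (0.47 log units; beyond the scatter) and a 2.9-fold higher number from compound 2 to compound 3 (0.46 log units; beyond the scatter), both modest and beyond the scatter, show that a 2-phenylethenyl group in that position went with weaker inhibition than either of the two substituted phenyl groups. Returning to a phenyl ring is therefore expected to bring the number back down by a modest step, a 2.8-fold lower number from compound 3 to compound 4 (0.44 log units; beyond the scatter). Compound 4 is expected to give about 4000 nM, within a range from 1500 nM to 11000 nM.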

Compound 4, concentration for 50% growth inhibition: 3540 nM
Compound 4: middle estimate off by 1.1-fold (0.05 log units), on the high side; the range from low to high includes it.
By their numbers in this assay, from the lowest: compounds 4, 1 and 2 (each within the scatter of the next); then compound 3.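

In this assay both a 1.1-fold lower number from compound 2 to compound 4 (0.03 log units; within the scatter) and a 1.0-fold lower number from compound 1 to compound 4 (0.02 log units; within the scatter) lie within the scatter, so 3,4-dimethoxyphenyl, which brings two hydrogen-bond acceptors, sits level with 2-chlorophenyl and 2-hydroxyphenyl on this saturated ring carbon. Within the data shown here, with a 3.1-fold lower number from compound 3 to compound 4 (0.49 log units; beyond the scatter) beyond the scatter, 2-phenylethenyl is the one group of the four that stands apart from three differently substituted phenyl rings. Nothing measured here explains this.
Still open, going by these compounds, is how an unsubstituted phenyl, a cyclohexyl ring or a short alkyl chain would behave at this carbon.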